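The source may hold more compounds than are shown below. What is called first, only, known or untested is meant among the compounds shown, and "the series" means these compounds.

Working notes on the series. In a functional assay on B16 cells (Mus musculus) for cytotoxicity, read by CCK-8 assay, with a stated time of 24 h (a lower number here means a stronger inhibitor, a higher number a weaker inhibitor), compound 1 (`COc1ccccc1Oc1c(N)nc(-c2ccccc2)nc1Cl`) reads 4610 nM and compound 2 (`COc1ccccc1Oc1c(N)nc(-c2ccc(I)cc2)nc1Cl`) reads 5400 nM while compound 3 (`COc1ccccc1Oc1c(N)nc(-c2ccccc2)nc1OCCO`) reads 31100 nM as the highest of the three numbers. Compound 3 is thus the weakest of the measured compounds.

Compound 4 (`COc1cccc(-c2nc(N)c(Oc3ccccc3OC)c(OCCO)n2)c1`) keeps the 2-hydroxyethoxy group of compound 3 and differs from it by methoxy in place of hydrogen on an aromatic carbon on an aromatic carbon of a six-membered aromatic ring of carbon only, meta to a large group, so that phenyl becomes 3-methoxyphenyl.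

Among the compounds with values here, no measured compound carries methoxy on that ring. Within the data shown here, the closest evidence is iodo in place of hydrogen on an aromatic carbon, which gave a 1.2-fold higher number from compound 1 to compound 2 (0.07 log units; within the scatter) as the only measured change on that ring. The other measured step, 2-hydroxyethoxy in place of chloro, gave a 6.7-fold higher number from compound 1 to compound 3 (0.83 log units; beyond the scatter) and sets the level from which compound 4 starts, not the size of the new step.

Among the measured compounds shown here, with compound 2 as the only guide, no step beyond the scatter is expected in this assay and no firm direction can be given. The estimated change is a 1.1-fold lower number from compound 3 to compound 4 (0.05 log units; within the scatter) and remains a weak expectation. For compound 4 the estimate is 28000 nM with an expected range from 12000 nM to 60000 nM for now.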

Compound 4, half-maximal inhibitory concentration: 30500 nM
Compound 4: middle estimate off by 1.1-fold (0.04 log units), on the low side; low and high end bracket the measured number.
By their numbers in this assay, from the lowest: compounds 1 and 2 (each within the scatter of the next); then compounds 4 and 3 (each within the scatter of the next).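

In this assay, the change from phenyl to 3-methoxyphenyl gives a 1.0-fold lower number from compound 3 to compound 4 (0.01 log units; within the scatter), so a methoxy group on this six-membered aromatic ring, meta to a large group, produces no readable change while the 2-hydroxyethoxy group is present. This is the first substitution on that ring read against compound 3, and it agrees with the iodo step on the chloro compounds, a 1.2-fold higher number from compound 1 to compound 2 (0.07 log units; within the scatter); across the steps shown, the only one beyond the scatter remains the replacement of chloro by 2-hydroxyethoxy, a 6.7-fold higher number from compound 1 to compound 3 (0.83 log units; beyond the scatter). Nothing available on these compounds offers an explanation for the flat reading at the ring.

As far as these compounds go, it remains open whether methoxy at this position would read the same with chloro in place of 2-hydroxyethoxy, since the present step rests on a single pair of compounds that both sit at the high end of the series. From the compounds shown here alone, it is also open whether an amine or a carboxylic acid on this ring would move the number, and whether a longer chain in place of 2-hydroxyethoxy would change the level set by compound 3.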